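From Piperazinyl to Pyridinyl: What to Expect of Compound 4

This account rests on a few compounds, and the source may have more. Where it says the series, first, only, none or still open, it means among the compounds named here.

Compound 1 `Cc1cc(C)c(NC(=O)N(Cc2ccc(N3CCN(C)CC3)cc2)C2CCCCCC2)c(C)c1`: in a functional assay on a cell-free system (plasma) with sterol O-acyltransferase, Soat (Rattus norvegicus) as the target (a lower number here means that less compound is needed, a higher number that more compound is needed for the effect), compound 1 gives > 1 mg/kg, a limit.
Compound 2 `COc1ccccc1CN(Cc1cccc(-c2cc[nH]n2)c1)C(=O)Nc1c(SC)cc(C)nc1SC`: in this assay compound 2 gives > 0.1 mg/kg, a limit.
Compound 3 `CSc1cc(C)nc(SC)c1NC(=O)N(Cc1ccc(F)cc1)Cc1cccc(-c2cc[nH]n2)c1`: in this assay compound 3 gives < 0.1 mg/kg, a limit.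

Compound 1 thus stands at the limit of > 1 mg/kg in this assay, at which 1 of the 3 values shown sits, and the other two values are likewise limits (the limit of > 0.1 mg/kg in this assay, at which 1 of the 3 values shown sits, and (the limit of < 0.1 mg/kg in this assay, at which 1 of the 3 values shown sits)). For the measured compounds named here, the only step between measured compounds, a number no higher from compound 2 to compound 3 (the limit leaves the size open), lies in another part of the molecule and its size is not readable. Compound 4 `Cc1cc(C)c(NC(=O)N(Cc2ccc(-c3cccnc3)cc2)C2CCCCCC2)c(C)c1` differs from compound 1 by pyridin-3-yl in place of 4-methylpiperazin-1-yl on an aromatic carbon. Going by the values given here, no measured step touches this position, so nothing shows how large a change to expect in this assay or in which direction. Compound 4 is therefore expected to sit near compound 1, a step that the limit leaves unreadable from compound 1 to compound 4, with an estimate of 1.5 mg/kg and a range from 0.3 mg/kg to 10 mg/kg.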

Compound 4, dose for half-maximal effect: 0.58 mg/kg
Compound 4: middle estimate off by 2.6-fold (0.41 log units), on the high side; the range from low to high includes it.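

In this assay, pyridin-3-yl on this aromatic carbon in place of 4-methylpiperazin-1-yl gives the first step seen at this position: an at least 1.7-fold lower number from compound 1 to compound 4 (0.23 log units; that floor lies within the scatter). The step shows that a six-membered aromatic ring can stand here and still give a measured number, and since only a floor is printed, the true size may be larger. Nothing given here offers a reason for the step. From the compounds shown here alone, how a morpholine ring or a plain phenyl ring would behave at this position stays open. So does whether the nitrogen of pyridin-3-yl matters to the result.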